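A few compounds are considered here, and "the series" means these few. Any claim that something is new, unique, unknown or untested is made for them only; others in the source may bear on it.

The measured compounds and their numbers in a functional assay on CCRF-CEM cells (Homo sapiens) for cytotoxicity, read by MTT assay, with a stated time of 24 h, tested at 50 uM; a lower number here means a stronger effect, a higher number a weaker effect of the compound at the concentration tested:
compound 1, `Cc1nc2c(Br)c(Br)c(Br)c(Br)c2n1CCCCC#N`, gives 55%
compound 2, `Cc1nc2c(Br)c(Br)c(Br)c(Br)c2n1CCC#N`, gives 2%
compound 3, `Cc1nc2c(Br)c(Br)c(Br)c(Br)c2n1CCCC#N`, gives 1%

Compound 1 stands highest of the three, so its effect is the weakest shown: the step of a number 53 percentage points lower from compound 1 to compound 2 (beyond the scatter) and the step of a number 54 percentage points lower from compound 1 to compound 3 (beyond the scatter) are both large and beyond the scatter, while a number 1 percentage points lower from compound 2 to compound 3 (within the scatter) lies within it. Compound 4, `N#CCCCCn1cnc2c(Br)c(Br)c(Br)c(Br)c21`, is not yet measured. It differs from compound 1 in one place: hydrogen in place of methyl on an aromatic carbon. For the measured compounds named here, the measured steps all concern the length of the chain that carries the nitrile; none touches the methyl on the shared core, so no measured step bears on this change, and the data give no guide to its direction. The expectation is therefore a step of no size beyond the scatter, no change at the digits printed from compound 1 to compound 4 (within the scatter), with a wide range to allow for the absence of any guiding step. Compound 4 is estimated at 55%, between 20% and 85%.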

Compound 4, a percentage reported as activity, at one concentration (the size of the read-out at that concentration, not a potency): 1%
For compound 4 the middle estimate is 54 percentage points above the measured one; measured number outside the range, below it.
By their numbers in this assay, from the lowest: compounds 3, 4 and 2 (each within the scatter of the next); then compound 1.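

The earlier steps shown here changed only the chain that carries the nitrile, and this one shows that a change on the shared core can also move the number. In this assay, hydrogen in place of methyl on the aromatic carbon between two ring nitrogen atoms gives a number 54 percentage points lower from compound 1 to compound 4 (beyond the scatter) with the 4-cyanobutyl group left in place. That single methyl therefore separates a weak effect from a strong one in this pair, but nothing measured here explains why.

As far as these compounds go, it remains open whether a larger group at this carbon, such as ethyl, or a different one, such as an amine, would behave like the methyl of compound 1 or the hydrogen of compound 4. From the compounds shown here alone, it is also open how either group would act with a chain longer than 4-cyanobutyl.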